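Replacing the pyrrolidine ring of compound 3

This account rests on a few compounds, and the source may have more. Where it says the series, first, only, none or still open, it means among the compounds named here.

- Compound 1 `CC(C)=CCCC(C)=CCNCCCN(C)CCCN`: > 150000 nM, a limit of the assay
- Compound 2 `CC(C)=CCC/C(C)=C\CCC(C)=CCNCCCCN`: 18100 nM
- Compound 3 `CC(C)=CCC/C(C)=C\CCC(C)=CCNCCCN1CCCC1`: 85300 nM

In a toxicity assay on CHO cells (Cricetulus griseus) for cytotoxicity, read by WST assay, with a stated time of 24 h (on this read-out lower numbers stand for stronger inhibition and higher numbers for weaker inhibition), compound 3 gives 85300 nM, the higher of the two actual numbers. The nearest value belongs to compound 2, at 18100 nM. Compound 1 gives only a limit of the assay, > 150000 nM.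

Compound 4 `CC(C)=CCC/C(C)=C\CCC(C)=CCNCCCN(C)CCCN` keeps the core of compound 3 and differs from it in one place: (3-aminopropyl)(methyl)amino in place of pyrrolidin-1-yl on a saturated chain carbon, three bonds along the chain from an amine nitrogen. The change sits on a saturated chain carbon, three bonds along the chain from an amine nitrogen.

Going by the values given here, one measured step bears directly on this change: a 4.7-fold higher number from compound 2 to compound 3 (0.67 log units; beyond the scatter). That modest step, beyond the scatter, brought in the pyrrolidin-1-yl group that compound 4 gives up, so a partial reversal is the reasonable expectation. Compound 1 carries the same (3-aminopropyl)(methyl)amino group on a different core, but its limit gives no step size and does not point towards a lower number.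

Resting on compound 2 and its step, the expected change in this assay is modest and downward, as a 2.8-fold lower number from compound 3 to compound 4 (0.45 log units; beyond the scatter). Compound 4 is estimated at 30000 nM, with an expected range from 11000 nM to 80000 nM.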

Compound 4, half-maximal inhibitory concentration: 10500 nM
The estimate for compound 4 lay 2.9-fold (0.46 log units) above the measured number; measured number outside the range, below it.
By their numbers in this assay, from the lowest: compounds 4 and 2 (each within the scatter of the next); then compound 3. At a limit, above all of these: compound 1.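

In this assay, (3-aminopropyl)(methyl)amino in place of pyrrolidin-1-yl gives an 8.1-fold lower number from compound 3 to compound 4 (0.91 log units; beyond the scatter), so the rise that came with pyrrolidin-1-yl at this saturated chain carbon is taken back in full rather than in part. The aminomethyl and (3-aminopropyl)(methyl)amino groups stand level here, with a 1.7-fold lower number from compound 2 to compound 4 (0.24 log units; within the scatter), and among the three groups seen at this place only pyrrolidin-1-yl, the one with a ring, stands apart. On the other side of the molecule, 3-methylbut-2-en-1-yl in place of hydrogen on a saturated chain carbon bound to a double-bonded chain carbon gives an at least 14-fold lower number from compound 1 to compound 4 (1.15 log units; beyond the scatter), a step that starts from a limit of the assay: the limit of > 150000 nM in this assay, at which 1 of the 4 values shown sits.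

The compounds shown leave open whether the ring itself sets pyrrolidin-1-yl apart, or the lack of a primary amine, which a dimethylamino group at this place, open-chain and without a primary amine, would help to separate. Equally open, on these data alone, is whether a further 3-methylbut-2-en-1-yl unit, giving a longer chain still, would carry the number lower or leave it where it stands.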